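This account rests on a few compounds, and the source may have more. Where it says the series, first, only, none or still open, it means among the compounds named here.

Compound 1 `Cc1cc(-c2ccccc2F)cc(C)c1Oc1cc(N)nc(Nc2ccc(C#N)cc2)n1` stands at the higher end of the two numbers recorded so far in a toxicity assay on MT4 cells (Homo sapiens) for cytotoxicity, read by MTT assay; on this read-out higher numbers stand for lower toxicity in this test and lower numbers for higher toxicity in this test: compound 1 gives 29300 nM. For the measured compounds named here, its only measured neighbour is compound 2 `Cc1ccc(-c2cc(C)c(Oc3cc(N)nc(Nc4ccc(C#N)cc4)n3)c(C)c2)cc1`, which in this assay gives 10000 nM; the change of 4-methylphenyl in place of 2-fluorophenyl on an aromatic carbon brought a 2.9-fold lower number from compound 1 to compound 2 (0.47 log units; beyond the scatter).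

Compound 3 `Cc1cc(-c2ccc(C#N)cc2)cc(C)c1Oc1cc(N)nc(Nc2ccc(C#N)cc2)n1` has not yet been tested in this assay. It differs from compound 1 by 4-cyanophenyl in place of 2-fluorophenyl on an aromatic carbon. Going by the values given here, the one measured step that bears on this change is the move from compound 1 to compound 2, which swapped the same 2-fluorophenyl for a different group at the same aromatic carbon and gave a modest fall in the number. Among the compounds with values here, since the group entering compound 3 is not the one entering compound 2, the expectation is guarded: a step of about the size seen from compound 1 to compound 2 in either direction, or none beyond the scatter, is judged plausible, so the expected step is a 1.2-fold lower number from compound 1 to compound 3 (0.07 log units; within the scatter). Compound 3 is therefore estimated at 25000 nM, within a range from 8000 nM to 80000 nM.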

Compound 3, half-maximal cytotoxic concentration: 18100 nM
Beside the measured number, compound 3's estimate is 1.4-fold (0.14 log units) above it; measured number inside the range.
By their numbers in this assay, from the lowest: compounds 2, 3 and 1 (each within the scatter of the next, the first and the last beyond it).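

In this assay, for the compounds shown here, placing 4-cyanophenyl on the aromatic carbon para to a large group gave a 1.6-fold lower number from compound 1 to compound 3 (0.21 log units; within the scatter), so this replacement of 2-fluorophenyl, unlike the replacement by 4-methylphenyl, leaves no step that can be told from the scatter. Going by these compounds alone, the two groups that differ only in what the phenyl ring carries, methyl or cyano, also cannot be separated at this position, since the change gave a 1.8-fold higher number from compound 2 to compound 3 (0.26 log units; within the scatter), and compound 3 therefore sits within the scatter of both earlier compounds while the one step beyond it remains a 2.9-fold lower number from compound 1 to compound 2 (0.47 log units; beyond the scatter). Nothing given here explains these numbers or the size of any of these steps.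

On these data alone, what stays open is whether the step beyond the scatter follows from the fluorine itself or from where a group sits on the phenyl ring, a question that 4-fluorophenyl at this position would address directly. As far as these compounds go, it is also open whether an amine or a carboxylic acid in place of the nitrile of 4-cyanophenyl would stay within the same narrow spread of numbers in this assay or move clearly outside it.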